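A Sulfur Stereocentre Awaits Its Reading

The compounds below may be only part of what the source reports. "The series", "measured", "known", "first", "only" and "open" are said of these compounds alone.

Of the compounds shown here, two have so far been measured in an ADME assay on HepG2 cells (Homo sapiens) for cytotoxicity, read by fluorescence, with a stated time of 72 h (a lower number here means a stronger inhibitor, a higher number a weaker inhibitor), and both returned numbers. Compound 1 `CCCCCCc1ccc(-c2ccc(S(=O)(=O)N3CCC[C@H]3C(=O)N[C@H](C(=O)N[C@@H](C)C(=O)NC(CC(N)=O)C(=O)N[C@@H](C)B3O[C@@H]4C[C@H]5C[C@H](C5(C)C)[C@]4(C)O3)[C@@H](C)O)cc2)cc1` gives 580 nM there, and compound 2 `CCCCCCc1ccc(-c2ccc([S@](=N)(=O)N3CCC[C@H]3C(=O)N[C@H](C(=O)N[C@@H](C)C(=O)NC(CC(N)=O)C(=O)N[C@@H](C)B3O[C@@H]4C[C@H]5C[C@H](C5(C)C)[C@]4(C)O3)[C@@H](C)O)cc2)cc1` gives 2950 nM there. Compound 2 therefore holds the higher of the two numbers, and the gap between them lies beyond the usual scatter.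

Compound 3 `CCCCCCc1ccc(-c2ccc([S@@](=N)(=O)N3CCC[C@H]3C(=O)N[C@H](C(=O)N[C@@H](C)C(=O)NC(CC(N)=O)C(=O)N[C@@H](C)B3O[C@@H]4C[C@H]5C[C@H](C5(C)C)[C@]4(C)O3)[C@@H](C)O)cc2)cc1` follows from compound 2 with the two compounds have the same atoms and bonds; at least one stereo element is drawn with a configuration in one of them and without one in the other: 1 of 11 stereo elements differ; a stereocentre at a sulfinyl sulfur is drawn R in compound 2 and S in compound 3 and nothing else, as a stereocentre at a sulfinyl sulfur is drawn R in compound 2 and S in compound 3. The two compounds have the same atoms and bonds. Among the compounds with values here, no measured pair yet differs only at this sulfur, so the data give no direct size for such a step. In this assay, within the data shown here, the expectation is anchored on compound 2 at 2950 nM as its closest reference, with compound 1 at 580 nM as the only lower number so far. The expected change is a 1.3-fold lower number from compound 2 to compound 3 (0.13 log units; within the scatter) in size, a small drop that is not expected to clear the scatter. For compound 3 the estimated value is 2200 nM with an expected range from 800 nM to 6000 nM in this reading.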

Compound 3, half-maximal inhibitory concentration: 2990 nM
Compound 3: the middle estimate sits 1.4-fold (0.13 log units) below what was measured, within the range that was stated.
By their numbers in this assay, from the lowest: compound 1; then compounds 2 and 3 (each within the scatter of the next).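

Compound 2 and compound 3 form the first pair shown that differs only at the sulfinyl sulfur, so this position now has a direct reading that the earlier compounds could not give. In this assay, the change from R to S at this stereocentre gives a 1.0-fold higher number from compound 2 to compound 3 (0.01 log units; within the scatter), and the two drawn configurations cannot be told apart by this read-out. This single pair says nothing about why the numbers agree, and the reading of the step carries one caution about how the pair is drawn: the fact that one of compounds 2 and 3 is drawn with a defined configuration and the other without, at the place where they differ

The compounds shown leave open whether the same agreement would hold in any read-out other than this assay, since the configuration at this sulfur has been compared in that one setting only. They also leave open how a methyl group or an acetyl group at this sulfur would read, and whether the two configurations would still match with such a group in place.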